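The compounds below may be only part of what the source reports. "The series", "measured", "known", "first", "only" and "open" are said of these compounds alone.

Compound 1 `CCCCCCCCN(C)C(=O)Cn1cc(Cc2cnc(O)nc2)c(=O)nc1SCc1ccc(F)cc1`: 34%
Compound 2 `CCCCCCCCN(C)C(=O)Cn1cc(Cc2cnc(=O)n(CC)c2)c(=O)nc1SCc1ccc(F)cc1`: 5%

In a functional assay on a cell-free system (plasma, Oryctolagus cuniculus) for inhibition of platelet-activating factor acetylhydrolase (Homo sapiens), tested at 100 nM (a lower number here means less inhibition, a higher number more inhibition at the concentration tested (going by the name of the read-out)), compound 2 gives 5%, the lower of the two numbers measured; compound 1 gives 34%, and the only step shown is a number 29 percentage points lower from compound 1 to compound 2 (beyond the scatter). Compound 3 `CCCCCCCCN(C)C(=O)Cn1cc(Cc2cnc(=O)n(CC(=O)NC)c2)c(=O)nc1SCc1ccc(F)cc1` differs from compound 2 in one place: methylcarbamoyl in place of methyl on a saturated chain carbon bound to an aromatic nitrogen. Among the compounds with values here, that step from compound 1 to compound 2 changed a different group at a different place, so no measured step bears on the present change, and nothing beyond the scatter is expected. Compound 3 is therefore expected to give about 8%, between 0% and 25%. This estimate means an expected step of a number 3 percentage points higher from compound 2 to compound 3 (within the scatter), within the scatter.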

Compound 3, a percentage reported as inhibition, at one concentration (the size of the read-out at that concentration, not a potency): 42%
Compound 3: middle estimate off by 34 percentage points, on the low side; measured number above the stated range.
By their numbers in this assay, from the lowest: compound 2; then compounds 1 and 3 (each within the scatter of the next).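

In this assay, the saturated chain carbon bound to an aromatic nitrogen proves sensitive to substitution: methylcarbamoyl in place of methyl gives a number 37 percentage points higher from compound 2 to compound 3 (beyond the scatter) and so reverses the low reading of compound 2. The remaining step, a number 8 percentage points higher from compound 1 to compound 3 (within the scatter), shows that the larger group carries no loss against compound 1. No measurement available here accounts for this change. Still open, from the compounds shown here alone, is whether the amide hydrogen is needed, and whether dimethylcarbamoyl, a carboxylic acid or a longer chain at this place would behave like methylcarbamoyl.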